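The source may hold more compounds than are shown below. What is called first, only, known or untested is meant among the compounds shown, and "the series" means these compounds.

Measured so far:
- compound 1 `CCOC(=O)c1c(-c2cc(F)cc(OC)c2)[nH]c2cc(OC)ccc2c1=O`: > 21500 nM (a limit)
- compound 2 `CCOC(=O)c1c(-c2cccc(OC)c2)[nH]c2cc(OC)ccc2c1=O`: > 21500 nM (a limit)

Both entries come from an ADME assay on HepG2 cells (Homo sapiens) for cytotoxicity, read by luminescence, with a stated time of 72 h; a higher number here means that more compound is needed for the effect, a lower number that less compound is needed. Compound 2 gives > 21500 nM, which is a limit of the assay and not a number. The whole record so far is the limit of > 21500 nM in this assay, at which 2 of the 2 values shown sit.

The next step leads to compound 3 `CCOC(=O)c1c(-c2cc(OC)cc(OC)c2)[nH]c2cc(OC)ccc2c1=O`, with methoxy in place of hydrogen on an aromatic carbon. Among the measured compounds shown here, the only measured step bearing on it is a step that the two limits leave unreadable from compound 1 to compound 2, a change at an aromatic carbon of the same ring, and it gives no size to carry over. No step beyond the scatter is therefore expected in this assay, and a further limit is the likeliest report. The expected size is a step that the limit leaves unreadable from compound 2 to compound 3. For compound 3 the estimated value is 25000 nM, with an expected range of 12000 nM to 50000 nM.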

Compound 3, half-maximal effective concentration: > 21500 nM
Compound 3: no number, only a limit (the forecaster's own chance of this, stated with the estimate: 85%); the middle value is on the limit's open side.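

In this assay compound 3 is reported only as a limit, so no step from compound 1 or compound 2 to compound 3 can be read: the limit of > 21500 nM in this assay, at which 3 of the 3 values shown sit.

The compounds shown leave open whether hydrogen, fluoro and methoxy at this aromatic carbon differ at all in this assay.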